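The source may report more compounds than this note shows. Statements on the series, on what has been measured and on what is new or still open speak of the compounds shown alone.

Of the compounds shown here, three have been measured in a functional assay on cells (Platelet, Homo sapiens) for inhibition; a higher number here means a weaker inhibitor, a lower number a stronger inhibitor.

Compound 1 `CCOC(=O)c1ccc(-c2nn(Cc3cccc(F)c3)c3ccccc23)cc1`: > 10000 nM, a limit.
Compound 2 `CCOC(=O)c1ccc(-c2nn(Cc3ccc(F)cc3)c3ccccc23)cc1`: > 10000 nM, a limit.
Compound 3 `CCOC(=O)c1ccc(-c2nn(CC)c3ccccc23)cc1`: > 10000 nM, a limit.

Compound 3 therefore stands at a limit and has no number, and the same holds for the other two compounds. Compound 4 `CCOC(=O)c1ccc(-c2nn(C(C)C)c3ccccc23)cc1` differs from compound 3 at one place: methyl in place of hydrogen on a saturated chain carbon bound to an aromatic nitrogen and a saturated chain carbon. This puts methyl in place of hydrogen on a saturated chain carbon bound to an aromatic nitrogen and a saturated chain carbon, which turns ethyl into isopropyl.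

The measured steps on this chain bear on the change, but none gives a size: a step that the two limits leave unreadable from compound 1 to compound 3, a step that the two limits leave unreadable from compound 2 to compound 3 and a step that the two limits leave unreadable from compound 1 to compound 2. All that can be read from them is the limit of > 10000 nM in this assay, at which 3 of the 3 values shown sit. They indicate no direction, so no shift beyond the scatter is expected in this assay. The expected step is a step that the limit leaves unreadable from compound 3 to compound 4, and compound 4 will most likely be reported only as a limit. For compound 4 the estimate is 20000 nM, with an expected range from 7000 nM to 60000 nM.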

Compound 4, half-maximal inhibitory concentration: > 10000 nM
Compound 4: only a limit was reported (the forecaster's own chance of this, stated with the estimate: 90%); the middle value is on the limit's open side.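

Compound 4, like compound 1, compound 2 and compound 3, is reported only as a limit, so no step between compound 4 and any of them can be read: the limit of > 10000 nM in this assay, at which 4 of the 4 values shown sit.

The compounds shown leave open how strongly any of them inhibits in this assay, and whether the group on the aromatic nitrogen matters there at all.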